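Butyl ether in place of 4-methoxybenzyl ether

The source may report more compounds than this note shows. Statements on the series, on what has been measured and on what is new or still open speak of the compounds shown alone.

Measured compounds:
compound 1, `[O-][n+]1nc(NCOCc2ccc(Cl)cc2)[n+]([O-])c2ccccc21`, 3260 nM in a functional assay on K562 cells (Homo sapiens) for cytotoxicity, read by MTT assay, with a stated time of 72 h; on this read-out lower numbers stand for stronger inhibition and higher numbers for weaker inhibition
compound 2, `COc1ccc(COCNc2n[n+]([O-])c3ccccc3[n+]2[O-])cc1`, 20100 nM in this assay
compound 3, `CC(C)CCOCNc1n[n+]([O-])c2ccccc2[n+]1[O-]`, 13100 nM in this assay

Compound 2 gives the highest of the three numbers in this assay. Compound 3 stands nearest to it, and the step between them is within the scatter: a 1.5-fold lower number from compound 2 to compound 3 (0.19 log units; within the scatter). Compound 1 lies furthest from compound 2, beyond the scatter: a 6.2-fold higher number from compound 1 to compound 2 (0.79 log units; beyond the scatter).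

Compound 4, `CCCCCOCNc1n[n+]([O-])c2ccccc2[n+]1[O-]`, has not yet been measured. Its difference from compound 2: butyl in place of 4-methoxyphenyl on a saturated chain carbon bound to an oxygen on a saturated carbon.

Among the compounds with values here, two measured steps bear on this change. Replacing the aromatic group on the ether carbon by a short alkyl chain gave a 1.5-fold lower number from compound 2 to compound 3 (0.19 log units; within the scatter) and a 4.0-fold higher number from compound 1 to compound 3 (0.60 log units; beyond the scatter). Within the data shown here, the butyl chain entering compound 4 is close to the isobutyl chain of compound 3, so the relevant comparison is the one from compound 2 to compound 3, which did not move beyond the scatter. The expected step is therefore small, a 1.4-fold lower number from compound 2 to compound 4 (0.16 log units; within the scatter), with no change beyond the scatter. Compound 4 is estimated at 14000 nM in this assay, with a range of 5000 nM to 40000 nM.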

Compound 4, half-maximal inhibitory concentration: 14500 nM
Estimate against measurement, compound 4: 1.0-fold (0.02 log units) below, within the range that was stated.
By their numbers in this assay, from the lowest: compound 1; then compounds 3, 4 and 2 (each within the scatter of the next).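

In this assay, butyl in place of 4-methoxyphenyl on a saturated chain carbon bound to an oxygen on a saturated carbon gives a 1.4-fold lower number from compound 2 to compound 4 (0.14 log units; within the scatter) and stays within the scatter, as does propyl in place of isopropyl, with a 1.1-fold higher number from compound 3 to compound 4 (0.04 log units; within the scatter) as its step. At this position, the 4-methoxyphenyl group and both alkyl chains therefore remain unseparated, while butyl in place of 4-chlorophenyl gives a 4.4-fold higher number from compound 1 to compound 4 (0.65 log units; beyond the scatter) and leaves compound 1 alone among the four as the one apart from the others. No measured evidence on the cause of these steps accompanies the series.

From the compounds shown here alone, whether a longer chain or a terminal amine at this position would move the number beyond the scatter remains open. Also open, going by these compounds, is whether a bromo or fluoro group on the aromatic ring would match the chloro group of compound 1.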